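The source may report more compounds than this note shows. Statements on the series, on what has been measured and on what is new or still open speak of the compounds shown alone.

Compound 1 `CC(C)c1n[nH]c2c(NCc3ccc(-c4ccccn4)cc3)nc(SCC(O)CO)nc12` is the reference point here. For the measured compounds named here, in a functional assay on HT cells (Homo sapiens) for antiproliferative activity, read by fluorescence, with a stated time of 72 h (a lower number here means a stronger inhibitor of growth, a higher number a weaker inhibitor of growth), compound 1 gives 21 nM, which is the lowest of the two numbers measured so far, and the only other measured compound lies well away from it. That other compound, compound 2 `CC(C)c1n[nH]c2c(NCc3ccc(-c4ccccn4)cc3)nc(SCC(N)CN)nc12`, differs from compound 1 in a single place: a 1,2-diaminoethyl stands in place of the 1,2-dihydroxyethyl on a saturated chain carbon bound to a sulfur. In this assay compound 2 gives 480 nM. The step from one to the other is a 23-fold higher number from compound 1 to compound 2 (1.36 log units; beyond the scatter), so swapping both hydroxy groups for amino groups clearly weakens growth inhibition.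

Compound 3 `CC(C)c1n[nH]c2c(NCc3ccc(-c4ccccn4)cc3)nc(SCC(O)CN)nc12` makes only part of that swap: amino in place of hydroxy on a saturated chain carbon, two bonds along the chain from an oxygen on a saturated carbon. One hydroxy group is kept and one becomes an amino group. Going by the values given here, the single measured step from compound 1 to compound 2 is the only guide, and it is large, so a rise in the number is expected for compound 3 as well, but a smaller one than the full swap produced, because compound 2 with both groups exchanged reached only 480 nM. The expected step is a 4.8-fold higher number from compound 1 to compound 3 (0.68 log units; beyond the scatter). Compound 3 is therefore estimated to give 100 nM, with a likely range from 35 nM to 300 nM.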

Compound 3, concentration for 50% growth inhibition: 55 nM
Compound 3: middle estimate off by 1.8-fold (0.26 log units), on the high side; the measured number falls inside the stated range.
By their numbers in this assay, from the lowest: compound 1; then compound 3; then compound 2.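

The exchange of one hydroxy group for an amino group is tolerated far better than the double exchange suggested: in this assay the step is a 2.6-fold higher number from compound 1 to compound 3 (0.42 log units; beyond the scatter), so compound 3 keeps much of the growth inhibition of compound 1. The two hydroxy positions also do not count equally here. Putting hydroxy in place of amino on the saturated chain carbon bound to two saturated chain carbons gives an 8.7-fold lower number from compound 2 to compound 3 (0.94 log units; beyond the scatter), a larger step than the first, so most of the loss seen in compound 2 goes with the amino group at that carbon once the other amino group is present. Nothing measured here explains why the two steps differ in size.

Still open, on these data alone, is how an amino group on that carbon behaves when the other hydroxy group stays in place, since the larger step was read only with an amino group already on the neighbouring chain position. Also open, as far as these compounds go, is whether a methoxy group or a carboxylic acid at either place would keep the number close to that of compound 1, which gives 21 nM.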